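This account rests on a few compounds, and the source may have more. Where it says the series, first, only, none or still open, it means among the compounds named here.

Measured so far:
Compound 1 `C[Si](C)(C)C#Cc1cn(C[C@H]2CN(c3ccc(C4=CCS(=O)(=O)CC4)c(F)c3)C(=O)O2)nn1`: in an assay for binding affinity to Amine oxidase [flavin-containing] A (Homo sapiens) (a lower number here means a stronger inhibitor, a higher number a weaker inhibitor), compound 1 gives > 200000 nM, which is a limit of the assay.
Compound 2 `CCc1cn(C[C@H]2CN(c3ccc(C4=CCS(=O)(=O)CC4)c(F)c3)C(=O)O2)nn1`: in this assay compound 2 gives > 200000 nM, which is also a limit of the assay.

Compound 2 thus stands only at a limit, and both values shown sit at the limit of > 200000 nM in this assay, at which 2 of the 2 values shown sit. The step that the two limits leave unreadable from compound 1 to compound 2 is therefore unreadable in size. Compound 3 `C#Cc1cn(C[C@H]2CN(c3ccc(C4=CCS(=O)(=O)CC4)c(F)c3)C(=O)O2)nn1` differs from compound 2 by ethynyl in place of ethyl on an aromatic carbon. Among the measured compounds shown here, no measured step gives a readable size for this change. Compound 3 is expected to stay near the limit, estimated at 300000 nM (range 80000 nM to 1200000 nM). This estimate means an expected step that the limit leaves unreadable from compound 2 to compound 3.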

Compound 3, inhibition constant: > 200000 nM
Compound 3: no number, only a limit; the forecaster's own chance of this, stated with the estimate: 85%; the middle value lies beyond the limit too.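

No step between compound 1, compound 2 and compound 3 can be read, because all three stand at the same limit rather than at a number: the limit of > 200000 nM in this assay, at which 3 of the 3 values shown sit.

These compounds leave open whether exchanging these groups changes inhibitor strength at all.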